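Chloro to trifluoromethyl on the urea aryl of compound 1

This account rests on a few compounds, and the source may have more. Where it says the series, first, only, none or still open, it means among the compounds named here.

Compound 1 `O=C(Nc1cccc(-n2cc(-c3ccncc3)c(-c3ccc(Cl)c(O)c3)n2)c1)Nc1ccc(Cl)c(Cl)c1` carries a 3,4-dichlorophenyl urea on the shared core. In a functional assay on SF-268 cells (Homo sapiens) for inhibition, read by sulforhodamine B assay, with a stated time of 48 h (on this read-out higher numbers stand for weaker inhibition of growth and lower numbers for stronger inhibition of growth), compound 1 gives 10900 nM, the highest number of the three measured. Compound 2 `O=C(Nc1cccc(-n2cc(-c3ccncc3)c(-c3ccc(Cl)c(O)c3)n2)c1)Nc1cc(C(F)(F)F)cc(C(F)(F)F)c1` gives 2690 nM in this assay, a gap from compound 1 beyond the scatter. Compound 3 `COc1cc(-c2nn(-c3cccc(NC(=O)Nc4cccc(C(F)(F)F)c4)c3)cc2-c2ccncc2)ccc1Cl` gives 5430 nM in this assay, which sits within the scatter of compound 1. Going by the values given here, no single-change step between measured compounds is available, so the direction of a change on this urea aryl rests on what the two values of compound 1 and compound 2 show.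

Compound 4 `O=C(Nc1cccc(-n2cc(-c3ccncc3)c(-c3ccc(Cl)c(O)c3)n2)c1)Nc1ccc(Cl)c(C(F)(F)F)c1` is the next compound to be measured. It differs from compound 1 in one place: trifluoromethyl in place of chloro on an aromatic carbon. Among the compounds with values here, the enters group is the one present twice in compound 2. A moderate lowering of the number is expected for compound 4, because compound 2 gives 2690 nM against compound 1 at 10900 nM. The step from compound 1 to compound 4 is estimated at a 2.2-fold lower number from compound 1 to compound 4 (0.34 log units; beyond the scatter). Compound 4 is expected near 5000 nM, within 2000 nM to 12000 nM.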

Compound 4, concentration for total growth inhibition: 6980 nM
Compound 4: middle estimate off by 1.4-fold (0.14 log units), on the low side; the range from low to high includes it.
By their numbers in this assay, from the lowest: compound 2; then compounds 3, 4 and 1 (each within the scatter of the next).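

In this assay, the series now has its first single-change step, at the carbon of the urea aryl ortho to a chloro group: a 1.6-fold lower number from compound 1 to compound 4 (0.19 log units; within the scatter). On this evidence, trifluoromethyl in place of chloro at this carbon does not separate compound 4 from compound 1, so a single exchange of this kind leaves the inhibition of growth unresolved within the usual scatter of the read-out. No measurement shown here offers an explanation for this result.

Still open, from the compounds shown here alone, is what a nitrile, a carboxylic acid or an amine would give on this same carbon of the 3,4-dichlorophenyl urea. Also open, going by these compounds, is whether the same exchange would give a step beyond the scatter if made at the remaining chloro group of compound 4.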